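This account rests on a few compounds, and the source may have more. Where it says the series, first, only, none or still open, it means among the compounds named here.

Three compounds already have a number in a functional assay on A-375 cells (Homo sapiens) for antiproliferative activity, read by MTT assay, with a stated time of 24 h; on this read-out lower numbers stand for stronger inhibition and higher numbers for weaker inhibition:

compound 1 `C#CCOc1ccc2c(=O)c(-c3cc(OC)c(OC)cc3OC)coc2c1` gives 3680 nM;
compound 2 `COc1ccc2c(=O)c(-c3cc(OC)c(OC)cc3OC)coc2c1` gives 2640 nM;
compound 3 `COc1cc(OC)c(-c2coc3cc(OCc4cccc(F)c4)ccc3c2=O)cc1OC` gives 1300 nM.

Compound 1 stands at the highest of these three numbers, which on this read-out means the weakest inhibition of cell growth among them. The shortest step away from it is a 1.4-fold lower number from compound 1 to compound 2 (0.14 log units; within the scatter), and this step stays within the scatter of repeated measurements. The longest is a 2.8-fold lower number from compound 1 to compound 3 (0.45 log units; beyond the scatter), a modest but real step toward lower numbers.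

Compound 4 `COc1cc(OC)c(-c2coc3cc(OCc4cccc(Cl)c4)ccc3c2=O)cc1OC` has not yet been measured. It differs from compound 1 in a single place: 3-chlorophenyl in place of ethynyl on a saturated chain carbon bound to an oxygen on an aromatic ring. The step that bears most directly on this change is a 2.8-fold lower number from compound 1 to compound 3 (0.45 log units; beyond the scatter), where a 3-fluorophenyl entered at the same place; a 2.0-fold lower number from compound 2 to compound 3 (0.31 log units; beyond the scatter) points the same way, with the same group entering in place of hydrogen. A 3-chlorophenyl at that place is therefore expected to give a modest step toward lower numbers, of roughly the same size, a 3.1-fold lower number from compound 1 to compound 4 (0.49 log units; beyond the scatter). On this basis compound 4 is expected to give about 1200 nM, with a likely range from 500 nM to 3000 nM.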

Compound 4, half-maximal inhibitory concentration: 980 nM
Estimate against measurement, compound 4: 1.2-fold (0.09 log units) above; the measured number falls inside the stated range.
By their numbers in this assay, from the lowest: compounds 4 and 3 (each within the scatter of the next); then compounds 2 and 1 (each within the scatter of the next).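

Compound 4 is the second compound with a halogen-bearing benzyl group at this place, and in this assay it again lands clearly below the two compounds with smaller groups there. Measured against the propargyl compound, the change to 3-chlorobenzyl gives a 3.8-fold lower number from compound 1 to compound 4 (0.57 log units; beyond the scatter) and counts as a modest gain, while 3-chlorophenyl in place of hydrogen on the same chain carbon gives a 2.7-fold lower number from compound 2 to compound 4 (0.43 log units; beyond the scatter) and is also modest, so among these four compounds the larger ring-bearing groups sit lower, and none of the four goes against this. The new information about the halogen itself comes from the change of chloro in place of fluoro on an aromatic carbon, which gives a 1.3-fold lower number from compound 3 to compound 4 (0.12 log units; within the scatter) and stays within the scatter, so this assay does not tell these two halogens apart at this place.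

The compounds shown leave open whether a plain benzyl without any halogen, a longer chain ending in an amine, or a carboxylic acid at this place would shift the number further in either direction. No measurement among those given offers a reason for any of these differences.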